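A few compounds are considered here, and "the series" means these few. Any claim that something is new, unique, unknown or untested is made for them only; others in the source may bear on it.

Three compounds share one core and differ only in the group hanging from their six-membered aromatic ring; all three have been measured in an assay on isolated protein for binding affinity to histone acetyltransferase KAT2B (Homo sapiens), read by fluorescence, tested at 10 uM; a higher number here means that the compound stabilises the target more against heat, a lower number that the compound stabilises the target less:

compound 1 `CN1C[C@H](Nc2nc3cc[nH]c3c(=O)n2C)C[C@H](c2cccc(Br)c2)C1` gives 7.5 degrees C
compound 2 `CCCCc1ccc([C@H]2C[C@@H](Nc3nc4cc[nH]c4c(=O)n3C)CN(C)C2)cc1` gives 4.6 degrees C
compound 3 `CN1C[C@H](Nc2nc3cc[nH]c3c(=O)n2C)C[C@H](c2ccc(Cl)c(C(F)(F)F)c2)C1` gives 6.6 degrees C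

Compound 2 stands lowest of the three. Its nearest neighbour is compound 3, whose number is higher by an amount beyond the scatter, and compound 1 lies further above it, also beyond the scatter. So among these three, compound 2 is the weakest stabiliser, and the ring substituent clearly matters.

Compound 4 `CN1C[C@H](Nc2nc3cc[nH]c3c(=O)n2C)C[C@H](c2ccc(O)cc2)C1` has not yet been measured. The change from compound 2 to compound 4 is hydroxy in place of butyl on an aromatic carbon, para to a large group. Among the compounds with values here, no pair of measured compounds shows exactly this kind of swap, so there is no directly comparable step to lean on; the two other measured compounds only show that a different group on this ring can raise the number.

With nothing closer to go by, the step from compound 2 to compound 4 is expected to be small, a number 0.80 degrees C higher from compound 2 to compound 4 (within the scatter), most likely within the scatter, with a slight lean upward. Compound 4 is therefore estimated at about 5.4 degrees C, with a range from 3.4 degrees C to 7.6 degrees C.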

Compound 4, shift of the target's melting temperature: 8.4 degrees C
Estimate against measurement, compound 4: 3.0 degrees C below; the measured number lies above the stated range.
By their numbers in this assay, from the lowest: compound 2; then compounds 3, 1 and 4 (each within the scatter of the next, the first and the last beyond it).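

In this assay, putting hydroxy in place of butyl on an aromatic carbon, para to a large group, gives a number 3.8 degrees C higher from compound 2 to compound 4 (beyond the scatter) and shows that this place on the ring can carry a much smaller group without any loss; here the number rises. Hydroxy brings a hydrogen-bond donor and acceptor, where butyl has neither, but this single swap cannot show whether those features matter. The second step, with 4-hydroxyphenyl in place of 3-bromophenyl on a saturated ring carbon, gives a number 0.90 degrees C higher from compound 1 to compound 4 (within the scatter) and so these two quite different ring groups cannot be told apart in this read-out. No separate measurement bears on what lies behind either step.

The compounds shown leave open whether the rise comes from losing butyl or from gaining hydroxy, and a plain methyl, a methoxy or an amine at the same place would help separate those two readings. They also leave open whether hydroxy would give a similar number on the ring carbon that carries bromine in compound 1.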